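This account rests on a few compounds, and the source may have more. Where it says the series, first, only, none or still open, it means among the compounds named here.

Within the data shown here, in an ADME assay (liver) for metabolic stability, with Liver microsome (Rattus norvegicus) as the target, using microsomes (a higher number here means faster removal of the compound, a lower number slower removal), three compounds have numbers so far. Compound 1 (`O=C(O)c1csc(-n2cc(-c3ccccc3)c3ccccc32)n1`) gives 2400 mL/min/kg, compound 2 (`COc1ccc2c(-c3ccccc3)nn(-c3nc(C(=O)O)cs3)c2c1`) gives 196 mL/min/kg, and compound 3 (`O=C(O)c1csc(-n2nc(-c3cccc(F)c3)c3ccccc32)n1`) gives 385 mL/min/kg. Compound 3 thus lies within the usual scatter of compound 2, and far under compound 1.

Compound 4 (`O=C(O)c1csc(-n2nc(C3=CCCC3)c3ccccc32)n1`) has not been measured. It carries cyclopent-1-en-1-yl in place of 3-fluorophenyl on an aromatic carbon. Among the measured compounds shown here, no two measured compounds differ in one place only, so no measured step shows what this swap does, and none of them has a non-aromatic ring at this place. With so little to go on, no step beyond the scatter is expected in this assay. The range is still kept wide, and wider on the high side, since compound 1 at 2400 mL/min/kg shows how high a number can go among these few compounds. The estimated step is small: a 1.1-fold higher number from compound 3 to compound 4 (0.04 log units; within the scatter). For compound 4 the expected value is 420 mL/min/kg, with an estimated range of 160 mL/min/kg to 1100 mL/min/kg.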

Compound 4, clearance: 196 mL/min/kg
Beside the measured number, compound 4's estimate is 2.1-fold (0.33 log units) above it, within the range that was stated.
By their numbers in this assay, from the lowest: compounds 2, 4 and 3 (each within the scatter of the next); then compound 1.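

Among these compounds, this is the only step that can be read at this position in this assay: cyclopent-1-en-1-yl in place of 3-fluorophenyl gives a 2.0-fold lower number from compound 3 to compound 4 (0.29 log units; within the scatter). The result shows that, on this aromatic carbon of the five-membered aromatic ring with 2 nitrogen, a six-membered aromatic ring of carbon only can be replaced by a five-membered non-aromatic ring of carbon only without a step beyond the scatter. This holds for this single pair and does not establish a wider pattern.

The compounds shown leave open how this assay responds at this place to a group without a ring, such as a longer carbon chain, or to a group containing an amine. They also leave open whether this swap would give a similar step on another core. No measurement shown here explains this result.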